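Methoxy on the Fused Ring: Compound 1 to Compound 4

The compounds below may be only part of what the source reports. "The series", "measured", "known", "first", "only" and "open" are said of these compounds alone.

Compound 1 `COc1ccc(-c2[nH]c3ccccc3c2/C=C(\C#N)S(=O)(=O)c2ccccc2)cc1` is the reference point of this set. In a functional assay on NCI-H522 cells (Homo sapiens) for inhibition, read by sulforhodamine B assay, with a stated time of 48 h (a higher number here means a weaker inhibitor of growth, a lower number a stronger inhibitor of growth), compound 1 gives 3000 nM, the lowest of the three numbers shown. Compound 3 `CCOC(=O)C(=Cc1c(-c2ccccc2)[nH]c2ccccc12)C(=O)OCC` gives 3400 nM and compound 2 `COc1ccc2[nH]c(-c3ccccc3)c(C=C(C#N)C#N)c2c1` gives 4600 nM; both lie within the scatter of compound 1, so the three cannot be ranked. Compound 4 `COc1ccc(-c2[nH]c3ccc(OC)cc3c2/C=C(\C#N)S(=O)(=O)c2ccccc2)cc1` is not yet measured. It differs from compound 1 by methoxy in place of hydrogen on an aromatic carbon, sitting meta to a fused ring and para to a fused ring. Among the measured compounds shown here, no measured pair shows this change, so its size is unknown; a move beyond the scatter is not expected in either direction. The expected step is no change at the digits printed from compound 1 to compound 4 (within the scatter). Compound 4 is therefore expected to give 3000 nM in this assay, between 1000 nM and 9000 nM.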

Compound 4, concentration for 50% growth inhibition: 1700 nM
Beside the measured number, compound 4's estimate is 1.8-fold (0.25 log units) above it; the measured number falls inside the stated range.
By their numbers in this assay, from the lowest: compounds 4, 1, 3 and 2 (each within the scatter of the next, the first and the last beyond it).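

Methoxy in place of hydrogen on an aromatic carbon, meta to a fused ring and para to a fused ring, gives a 1.8-fold lower number from compound 1 to compound 4 (0.25 log units; within the scatter) in this assay. Among the compounds shown here, this is the first measured pair for this change, and it shows that the position carries methoxy with no move beyond the scatter.

Still open, going by these compounds, is whether an amine, a carboxylic acid or a longer chain at this position would give a step beyond the scatter. Nothing at hand bears on the reason for this result.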